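A few compounds are considered here, and "the series" means these few. Any claim that something is new, unique, unknown or untested is made for them only; others in the source may bear on it.

Compound 1 `O=C(CSc1nc(Nc2ccccc2)c2ccccc2n1)Nc1ccccc1Cl`: 24800 nM
Compound 2 `COc1cccc(NC(=O)CSc2nc(Nc3ccccc3)c3ccccc3n2)c1`: 10000 nM

Both numbers come from a functional assay on MGC-803 cells (Homo sapiens) for inhibition, read by MTT assay, with a stated time of 72 h; a lower number here means a stronger inhibitor, a higher number a weaker inhibitor. Among the measured compounds shown here, compound 2 holds the lower of the two; the only step between them, a 2.5-fold lower number from compound 1 to compound 2 (0.39 log units; beyond the scatter), separates it from compound 1, which sits higher.

Compound 3 `O=C(CSc1nc(Nc2ccccc2)c2ccccc2n1)Nc1ccc(Br)cc1` has not yet been measured. It differs from compound 2 in one place: 4-bromophenyl in place of 3-methoxyphenyl on an amide-type nitrogen. For the measured compounds named here, the single measured step, a 2.5-fold lower number from compound 1 to compound 2 (0.39 log units; beyond the scatter), concerns a different exchange on that same amide-type nitrogen, 3-methoxyphenyl for 2-chlorophenyl, and says nothing directly about 4-bromophenyl. Going by the values given here, no measured step therefore fixes a direction; the two numbers merely mark the span these aryl amides have occupied so far. Compound 3 is expected to fall inside that span, with the estimated step of a 1.4-fold higher number from compound 2 to compound 3 (0.15 log units; within the scatter) staying within the scatter. The estimate for compound 3 in this assay is 14000 nM, with a range from 5000 nM to 40000 nM.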

Compound 3, half-maximal inhibitory concentration: 19300 nM
Beside the measured number, compound 3's estimate is 1.4-fold (0.14 log units) below it, within the range that was stated.
By their numbers in this assay, from the lowest: compounds 2, 3 and 1 (each within the scatter of the next, the first and the last beyond it).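

In this assay, 4-bromophenyl on the amide-type nitrogen can be told apart from neither earlier aryl group: exchanging 3-methoxyphenyl for it gives (a 1.9-fold higher number from compound 2 to compound 3 (0.29 log units; within the scatter)), and exchanging 2-chlorophenyl for it gives (a 1.3-fold lower number from compound 1 to compound 3 (0.11 log units; within the scatter)). Among the compounds shown here, compound 3 therefore adds a third aryl group at this position without a step beyond the scatter, and the only such separation among the three remains the one between compound 1 and compound 2. Nothing available explains how these aryl groups relate to the numbers.

The three rings differ in both their substituent and its place, so the compounds shown do not separate these two changes. Also open, on these data alone, is how the number would respond to a carboxylic acid on the ring, or to a morpholine or a longer alkyl chain replacing the ring on this nitrogen.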